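The compounds below may be only part of what the source reports. "The series", "measured", "known", "first", "only" and "open" are said of these compounds alone.

Working notes on the series. Among the measured compounds shown here, compound 1 `CCCCCCC(=O)Nc1ccn([C@@H]2CO[C@H](CO)O2)c(=O)n1` carries a hexyl on the carbonyl carbon; in a functional assay on A549 cells (Homo sapiens) for cytotoxicity, read by sulforhodamine B assay, with a stated time of 72 h (a higher number here means a weaker inhibitor, a lower number a stronger inhibitor), compound 1 gives 1040 nM, the highest of the two numbers so far. Compound 2 `CCCCCCCCCCCCCCCCCCCC(=O)Nc1ccn([C@@H]2CO[C@H](CO)O2)c(=O)n1`, with the long chain, gives in this assay 30 nM, a lower number beyond the scatter. Compound 3 `COc1ccc(C(=O)Nc2ccn([C@@H]3CO[C@H](CO)O3)c(=O)n2)cc1` is not yet measured; the change from compound 1 is 4-methoxyphenyl in place of hexyl on a carbonyl carbon. No comparable aryl amide exists in the set, so the step is expected to be small, a 1.4-fold higher number from compound 1 to compound 3 (0.16 log units; within the scatter), if anything toward a slightly higher number. Compound 3 is therefore estimated at 1500 nM, within 500 nM to 5000 nM.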

Compound 3, half-maximal inhibitory concentration: 3500 nM
Estimate against measurement, compound 3: 2.3-fold (0.37 log units) below; low and high end bracket the measured number.
By their numbers in this assay, from the lowest: compound 2; then compound 1; then compound 3.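

In this assay, among the compounds shown here, the carbonyl carbon now carries an aromatic ring for the first time, and 4-methoxyphenyl in place of hexyl gives a 3.4-fold higher number from compound 1 to compound 3 (0.53 log units; beyond the scatter). For the compounds shown here, this place therefore responds to a change in the type of group, not only in a chain, and compound 3 has the highest number of the series so far. Nothing available bears on the reason for this rise.

Going by these compounds, whether the step belongs to the ring or to its methoxy remains open, and a plain phenyl would separate the two. On these data alone, how a decyl chain on the carbonyl carbon would read also remains open.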